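Weak growth inhibitors of a shared core against leukaemia cells

The source may hold more compounds than are shown below. What is called first, only, known or untested is meant among the compounds shown, and "the series" means these compounds.

Compound 1 `COc1ccccc1Nc1nc(-c2cccc(F)c2)nc2ccc(F)cc12` was tested in a functional assay on HL-60 cells (Homo sapiens) for cytotoxicity, read by MTT assay, with a stated time of 48 h; a lower number here means a stronger inhibitor, a higher number a weaker inhibitor. In this assay compound 1 gives > 50000 nM, which is a limit of the assay rather than a number. Two related compounds share its core. Compound 2 `Fc1cccc(-c2nc(Nc3ccc(Cl)cc3)c3cc(F)ccc3n2)c1` gives 45700 nM in this assay. Compound 3 `Nc1ccc(Nc2nc(-c3cccc(F)c3)nc3ccc(F)cc23)cc1` gives > 50000 nM in this assay, again a limit. The step of an at least 1.0-fold lower number from compound 1 to compound 2 (0.03 log units; that floor lies within the scatter) and the step of an at least 1.0-fold higher number from compound 2 to compound 3 (0.03 log units; that floor lies within the scatter) both rest on such limits, and the step that the two limits leave unreadable from compound 1 to compound 3 cannot be read at all; the picture is summed up by the limit of > 50000 nM in this assay, at which 2 of the 3 values shown sit.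

Compound 4 `Cc1cccc(Nc2nc(-c3cccc(F)c3)nc3ccc(F)cc23)c1` is not yet measured. It differs from compound 1 in one place: 3-methylphenyl in place of 2-methoxyphenyl on a nitrogen on an aromatic ring. The measured steps that bear on this change, from compound 1 to compound 2 and to compound 3, all stay at or near the limit, so no shift beyond the scatter is expected from the step of a number no higher from compound 1 to compound 4 (the limit leaves the size open). Compound 4 is therefore expected to give about 50000 nM, within a range from 15000 nM to 200000 nM, most likely reported only as a limit.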

Compound 4, half-maximal inhibitory concentration: > 50000 nM
Compound 4 gave a limit, no number; the forecaster's own chance of this, stated with the estimate: 70%; the middle value lies on the limit itself.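

Replacing 2-methoxyphenyl with 3-methylphenyl removes the oxygen of the group on this nitrogen, yet the result in this assay stays a limit, so this change produces no readable gain in potency. Going by these compounds alone, the only step that can be read is an at least 1.0-fold higher number from compound 2 to compound 4 (0.03 log units; that floor lies within the scatter), so 3-methylphenyl and 4-chlorophenyl cannot be told apart here, while the steps to compound 4 from compound 1 and compound 3 cannot be read, with limits at both ends. A third substituted phenyl group on this nitrogen has now joined the others at the top of the measurable range: the limit of > 50000 nM in this assay, at which 3 of the 4 values shown sit.

As far as these compounds go, it remains open whether any group on this nitrogen can give a clearly lower number in this assay. A carboxylic acid on the phenyl ring, or a longer chain ending in an amine in place of that ring, would test this.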